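One Methoxy Fewer: An Expected Loss of Cell Inhibition

The compounds below may be only part of what the source reports. "The series", "measured", "known", "first", "only" and "open" are said of these compounds alone.

compound 1 `COc1cc(C2=NOC(c3c[nH]c4ccccc34)C2)cc(OC)c1OC` — 5000 nM
compound 2 `COc1ccc2c(c1)c(C1CC(c3ccncc3)=NO1)cn2Cc1ccc(Cl)cc1` — 14200 nM

In a functional assay on HEK293 cells (Homo sapiens) for inhibition, read by MTT assay, with a stated time of 48 h (on this read-out lower numbers stand for stronger inhibition and higher numbers for weaker inhibition), compound 1 gives 5000 nM, the lowest of the two numbers shown. Compound 2 gives 14200 nM, a higher number that lies beyond the scatter. Compound 3 `COc1ccc(C2=NOC(c3c[nH]c4ccccc34)C2)cc1OC` differs from compound 1 by hydrogen in place of methoxy on an aromatic carbon. Going by the values given here, no measured pair shows this change, so the size of the step is not anchored; a modest shift toward a higher number is expected, around the edge of the scatter. Compound 3 is therefore expected to give 10000 nM (range 3500 nM to 30000 nM), an estimated step of a 2.0-fold higher number from compound 1 to compound 3 (0.30 log units; within the scatter).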

Compound 3, half-maximal inhibitory concentration: > 100000 nM
Compound 3: a limit, no number; the forecaster's own chance of this, stated with the estimate: 15%; middle value at least 10-fold (1.00 log units) away from the limit.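

In this assay, this one position on the six-membered aromatic ring, ortho to a methoxy group and meta to a large group, proves highly sensitive: hydrogen in place of the methoxy gives an at least 20-fold higher number from compound 1 to compound 3 (1.30 log units; beyond the scatter). Compound 3 stands at a limit of the assay and not at a number: the limit of > 100000 nM in this assay, at which 1 of the 3 values shown sits. A single methoxy at this place therefore separates measurable inhibition from none within the range read.

Going by these compounds, how far the step extends past that limit stays open. So does whether a hydroxyl, a fluorine or an ethoxy at this place would keep the inhibition of compound 1.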